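The source may report more compounds than this note shows. Statements on the series, on what has been measured and on what is new or still open speak of the compounds shown alone.

Compound 1 `Cc1ccccc1NC(=O)N[C@H](C)c1ccccc1` gives 100% in an ADME assay on the whole organism with Oryza sativa as the target, tested at 1 uM; a lower number here means a stronger effect, a higher number a weaker effect of the compound at the concentration tested.
Compound 2 `C[C@@H](NC(=O)Nc1ccc(F)cc1)c1ccccc1` gives 96% in this assay.
Compound 3 `C[C@@H](NC(=O)Nc1ccc(F)cc1F)c1ccccc1` gives 100% in this assay.

Compound 3 stands level with compound 1 at the digits shown, the two together being the highest of the three numbers; compound 2 lies a little lower, but within the scatter. Compound 4 `Cc1cc(F)ccc1NC(=O)N[C@H](C)c1ccccc1` differs from compound 3 in one place: methyl in place of fluoro on an aromatic carbon. For the measured compounds named here, only one measured step exists, a number 4 percentage points higher from compound 2 to compound 3 (within the scatter), and it is within the scatter; it concerns fluoro entering for hydrogen, not methyl for fluoro, so it bears on the present change only loosely. Going by the values given here, no measured step shows methyl in place of fluoro. The step from compound 3 to compound 4 is therefore expected to be no change at the digits printed from compound 3 to compound 4 (within the scatter), nothing beyond the scatter. Compound 4 is estimated at 100%, between 90% and 100%.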

Compound 4, a percentage reported as activity, at one concentration (the size of the read-out at that concentration, not a potency): 100%
Compound 4: the middle estimate sits on the measured number at the digits printed; the measured number falls inside the stated range.
By their numbers in this assay, from the lowest: compounds 2, 1, 3 and 4 (each within the scatter of the next).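

At this position, on an aromatic carbon ortho to a large group, methyl in place of fluoro gives no change at the digits printed from compound 3 to compound 4 (within the scatter), and methyl in place of hydrogen gives a number 4 percentage points higher from compound 2 to compound 4 (within the scatter). Fluoro in place of hydrogen now also appears on a second core, giving no change at the digits printed from compound 1 to compound 4 (within the scatter). In this assay, the two readings of that change agree: the same change on two cores in this assay, a number 4 percentage points higher (within the scatter) from compound 2 to compound 3 and no change at the digits printed (within the scatter) from compound 1 to compound 4, 4 percentage points apart, within the scatter of two such steps

The compounds shown leave open whether an amine, a carboxylic acid or a longer chain at this position would move the number beyond the scatter. For the compounds shown here, every step so far lies within it.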